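This account rests on a few compounds, and the source may have more. Where it says the series, first, only, none or still open, it means among the compounds named here.

Compound 1 `COc1ccc(-c2cc3ccccc3nc2/C=C/C(=O)c2ccccc2)cc1` is the starting point of this comparison. Within the data shown here, in a functional assay on H184B5F5/M10 cells (Homo sapiens) for antiproliferative activity, read by XTT assay, with a stated time of 72 h (on this read-out higher numbers stand for weaker inhibition and lower numbers for stronger inhibition), compound 1 gives 8560 nM, the highest of the two numbers so far obtained. Among the measured compounds shown here, its nearest neighbour, compound 2 `COc1ccc(-c2cc3ccccc3nc2/C=C/C(=O)c2c(OC)cccc2OC)cc1`, gives 4470 nM in this assay, and the single measured step, a 1.9-fold lower number from compound 1 to compound 2 (0.28 log units; within the scatter), is a change at the same carbonyl carbon that stays within the scatter. Compound 3 `COc1ccc(-c2cc3ccccc3nc2/C=C/C(=O)c2ccc(Br)s2)cc1` differs from compound 1 by 5-bromothiophen-2-yl in place of phenyl on a carbonyl carbon. For the measured compounds named here, no measured step tests this particular exchange; the only step so far measured, a 1.9-fold lower number from compound 1 to compound 2 (0.28 log units; within the scatter), concerns a different group at the same place and was small. On that evidence, the step of a 1.3-fold lower number from compound 1 to compound 3 (0.12 log units; within the scatter) is expected to stay within the scatter, with no direction that the data support. Compound 3 is therefore estimated at 6500 nM in this assay, within a range from 2000 nM to 20000 nM.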

Compound 3, half-maximal inhibitory concentration: 9380 nM
Compound 3: middle estimate off by 1.4-fold (0.16 log units), on the low side; low and high end bracket the measured number.
By their numbers in this assay, from the lowest: compounds 2, 1 and 3 (each within the scatter of the next, the first and the last beyond it).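

In this assay, the carbonyl carbon takes a five-membered aromatic ring bearing bromine in place of phenyl with no change beyond the scatter, a 1.1-fold higher number from compound 1 to compound 3 (0.04 log units; within the scatter). The same position also gives its first step beyond the scatter, though a modest one, a 2.1-fold higher number from compound 2 to compound 3 (0.32 log units; beyond the scatter), so 5-bromothiophen-2-yl and 2,6-dimethoxyphenyl can be told apart even though each stays within the scatter of phenyl in compound 1. Nothing available explains either step.

The compounds shown leave open what an unsubstituted thiophen-2-yl or a pyridinyl ring would give on this carbonyl carbon, so the bromine cannot be separated from the ring that holds it. Also open, as far as these compounds go, is whether a group of another kind there, such as an amine or a carboxylic acid, would move the number beyond the scatter of compound 1.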